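Cyano for methyl on selenium in a small series

The source may hold more compounds than are shown below. What is called first, only, known or untested is meant among the compounds shown, and "the series" means these compounds.

In a functional assay on MDA-MB-231 cells (Homo sapiens) for inhibition, read by MTT assay, with a stated time of 48 h (on this read-out lower numbers stand for stronger inhibition and higher numbers for weaker inhibition), three compounds have been measured:
Compound 1, `C[Se]c1ccc(N(C)c2nc(C3CC3)nc3ccccc23)cc1`, gives 18 nM.
Compound 2, `Cc1nc(N(C)c2ccc([Se]C#N)c(Cl)c2)c2ccccc2n1`, gives 9 nM.
Compound 3, `C[Se]c1ccc(N(C)c2nc(C)nc3ccccc23)cc1Cl`, gives 7 nM.

Compound 3 and compound 2 differ in one place only: cyano in place of methyl on a selenium. That change made a 1.3-fold higher number from compound 3 to compound 2 (0.11 log units; within the scatter). Compound 1 carries the methyl on selenium as well, but the difference between its core and the core of compound 3 is not broken down here; compound 1 stands furthest from compound 3, the gap lying beyond the scatter, while its gap to compound 2 lies within it.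

Compound 4, `CN(c1ccc([Se]C#N)cc1)c1nc(C2CC2)nc2ccccc12`, is not yet measured. It differs from compound 1 by cyano in place of methyl on a selenium, the same change as that from compound 3 to compound 2. Because that earlier step was a 1.3-fold higher number from compound 3 to compound 2 (0.11 log units; within the scatter), a similar small step is expected in this assay, namely a 1.2-fold higher number from compound 1 to compound 4 (0.09 log units; within the scatter). Compound 4 is therefore estimated at 22 nM, expected between 9 nM and 55 nM.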

Compound 4, half-maximal inhibitory concentration: 29 nM
Estimate against measurement, compound 4: 1.3-fold (0.12 log units) below; the range from low to high includes it.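

In this assay, cyano in place of methyl on the selenium made a 1.6-fold higher number from compound 1 to compound 4 (0.21 log units; within the scatter). Set beside the earlier case, the change carries from one core to the other with no difference that can be told from scatter: the same change on two cores in this assay, a 1.3-fold higher number (0.11 log units; within the scatter) from compound 3 to compound 2 and a 1.6-fold higher number (0.21 log units; within the scatter) from compound 1 to compound 4, 1.3-fold (0.10 log units) apart, within the scatter of two such steps. For the compounds shown here, each step also lies within the scatter on its own, so the pair shows only that this change left the number close to where it stood on these two cores; it does not show that cyano and methyl differ here, and it says nothing about any other core.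

The compounds shown leave open how a longer chain on the selenium would compare with methyl and cyano. They also leave open how the same change would behave on a core carrying an amine or a carboxylic acid.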